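Opening the ring of compound 1: what to expect

The source may hold more compounds than are shown below. What is called first, only, known or untested is meant among the compounds shown, and "the series" means these compounds.

Measured in a functional assay on KB cells (Homo sapiens) for cytotoxicity; on this read-out lower numbers stand for stronger inhibition and higher numbers for weaker inhibition:
- compound 1 `CC1=C(O)/C(=C/[C@@H](C)CCC/C(C)=C\C=C\[C@]2(C)CCCc3ccoc32)OC1=O`: >= 1 ug/mL
- compound 2 `CC1=C(O)/C(=C/[C@@H](C)CCC/C(C)=C/C=C/[C@]2(C)CCCc3ccoc32)OC1=O`: >= 1 ug/mL

In this assay, compound 1 stands at >= 1 ug/mL, which is a limit and not a number. Compound 2 gives >= 1 ug/mL, also a limit. Compound 3 `CCC(O)C(=O)C[C@@H](C)CCC/C(C)=C\C=C\[C@]1(C)CCCc2ccoc21` differs from compound 1 by a group of 7 heavy atoms (5 carbon, 2 oxygen; no ring) in place of a group of 9 heavy atoms (6 carbon, 3 oxygen; one five-membered non-aromatic ring with 1 hetero atom), on a saturated chain carbon bound to two saturated chain carbons. For the measured compounds named here, the only measured step is a step that the two limits leave unreadable from compound 1 to compound 2, and it reflects (the fact that compounds 1 and 2 differ only in the configuration as drawn), so it says nothing about this larger change. Going by the values given here, with the limit of >= 1 ug/mL in this assay, at which 2 of the 2 values shown sit, as the only guide, no readable step size or direction can be carried over to this assay, and weak inhibition is expected to continue. Compound 3 is estimated at 3 ug/mL, within a range of 1 ug/mL to 15 ug/mL. The expected change is a step that the limit leaves unreadable from compound 1 to compound 3.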

Compound 3, half-maximal inhibitory concentration: < 1 ug/mL
Compound 3 ended at the assay's limit; the forecaster's own chance of this, stated with the estimate: 70%; middle value at least 3.0-fold (0.47 log units) from the limit.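

Compound 3 shows that the five-membered ring of compound 1 can be given up without a loss in this assay: putting the open ((1-hydroxypropyl)carbonyl)methyl group in its place gives a number no higher from compound 1 to compound 3 (the limit leaves the size open). For the compounds shown here, the earlier pair differed only in the configuration of a double bond, so this is the first direction seen for a change on this saturated chain carbon bound to two saturated chain carbons. The size of the step cannot be read.

On these data alone, it remains open whether the hydroxyl or the carbonyl of the new group matters for this result. As far as these compounds go, how an amine or a carboxylic acid would behave in the same place also remains open.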